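This account rests on a few compounds, and the source may have more. Where it says the series, first, only, none or still open, it means among the compounds named here.

Working notes on the series. Compound 1 `O=S1(=O)C=C(OCc2ccccc2)C(Cc2ccccc2)(Cc2ccccc2)O1` carries two benzyl groups on the saturated ring carbon; in an ADME assay on HEL cells (Homo sapiens) for cytotoxicity, with a stated time of 3 days (on this read-out lower numbers stand for higher toxicity in this test and higher numbers for lower toxicity in this test), compound 1 gives 200000 nM. Compound 2 `CCC1(Cc2ccccc2)OS(=O)(=O)C=C1OCc1ccccc1` has ethyl in place of one benzyl. For compound 2 the read-out is only a limit, >= 50000 nM. The step that the limit leaves unreadable from compound 1 to compound 2 is therefore not readable in size; the limit of >= 50000 nM in this assay, at which 1 of the 3 values shown sits, blocks it. Compound 3 `CCC1(Cc2ccccc2)OS(=O)(=O)C=C1OCc1ccc(OC)cc1` adds methoxy on an aromatic carbon. For compound 3 the read-out is again a limit, >= 200000 nM. The step that the two limits leave unreadable from compound 2 to compound 3 is likewise unreadable since the limit of >= 200000 nM in this assay, at which 1 of the 3 values shown sits, and the limit of >= 50000 nM in this assay, at which 1 of the 3 values shown sits, sit on its two ends. For the measured compounds named here, compound 2 thus stands at a limit rather than at a number, and one of the two other values shown is also a limit; the only plain number in the set is that of compound 1, and no value among the three points to marked toxicity.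

Compound 4 `CC1(Cc2ccccc2)OS(=O)(=O)C=C1OCc1ccccc1` is the next member: hydrogen in place of methyl on a saturated chain carbon bound to a saturated ring carbon. Both measured steps around compound 2 are unreadable, so neither gives a size to lean on for this change, and nothing shown argues for a move beyond the scatter in this assay in either direction. Compound 4 is expected to give 100000 nM, with a range of 30000 nM to 300000 nM. The expected step is a step that the limit leaves unreadable from compound 2 to compound 4, within the scatter. Most likely the read-out for compound 4 will again be a limit.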

Compound 4, minimum cytotoxic concentration: > 400000 nM
Compound 4: a limit, no number; the forecaster's own chance of this, stated with the estimate: 70%; at least 4.0-fold (0.60 log units) between middle value and limit.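

Compound 4 reads only as a limit in this assay, > 400000 nM, and with methyl in place of ethyl on the saturated ring carbon the read-out stays a limit, so this shorter group gives no sign of marked toxicity in this test. For the compounds shown here, the one step that can be read at this place is an at least 2.0-fold higher number from compound 1 to compound 4 (0.30 log units; that floor lies within the scatter), which gives that change a direction but no size beyond the scatter, while the other steps, including the change from ethyl to methyl, cannot be read. With the benzyl group kept on the ring carbon, the ethyl and methyl compounds therefore give only a shared absence of a low number, not a trend, and the highest limit in the set belongs to compound 4: the limit of > 400000 nM in this assay, at which 1 of the 4 values shown sits.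

The compounds shown leave open how large the difference between ethyl and methyl at this place really is, since plain numbers for both would be needed to size it. They also leave open whether an amine, a carboxylic acid or a chain longer than ethyl on that saturated chain carbon would bring the read-out down to a plain number.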